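Changing the Group on the Ring Nitrogen of Compound 2

The source may hold more compounds than are shown below. What is called first, only, known or untested is meant among the compounds shown, and "the series" means these compounds.

Of the compounds shown here, three sharing one core have been tested in a functional assay on MKN-74 cells (Homo sapiens) for antiproliferative activity, with a stated time of 24 h; on this read-out higher numbers stand for weaker inhibition and lower numbers for stronger inhibition. Compound 1 `NC(=O)c1c(NC(=O)c2ccccc2Cl)sc2c1CCN(Cc1ccc(Cl)cc1Cl)C2` gives 16300 nM. Compound 2 `NC(=O)c1c(NC(=O)c2ccc(C(F)(F)F)cc2)sc2c1CCN(Cc1ccc(Cl)cc1Cl)C2` gives 10900 nM, and compound 3 `NC(=O)c1c(NC(=O)c2cccc([N+](=O)[O-])c2)sc2c1CCN(Cc1ccc(Cl)cc1Cl)C2` gives 16500 nM. Compound 2 has the lowest of the three numbers, but its steps to the others, a 1.5-fold lower number from compound 1 to compound 2 (0.17 log units; within the scatter) and a 1.5-fold higher number from compound 2 to compound 3 (0.18 log units; within the scatter), both lie within the scatter, so the three cannot be told apart. Compound 4 `NC(=O)c1c(NC(=O)c2ccc(C(F)(F)F)cc2)sc2c1CCN(C(=S)Nc1ccccc1Cl)C2` differs from compound 2 at another place: a group of 10 heavy atoms (7 carbon, 1 nitrogen, 1 sulfur, 1 chlorine; one six-membered aromatic ring of carbon only) in place of a group of 9 heavy atoms (7 carbon, 2 chlorine; one six-membered aromatic ring of carbon only), on an amine nitrogen in a ring. Going by the values given here, every measured step changed only the group on the carbonyl carbon, and none touched the amine nitrogen in the ring, so no measured step bears on this change. The expectation rests on compound 2 alone and carries a wide range. Compound 4 is expected to give 11000 nM, between 3000 nM and 40000 nM. This would be an expected step of a 1.0-fold higher number from compound 2 to compound 4 (0.00 log units; within the scatter).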

Compound 4, half-maximal inhibitory concentration: 16400 nM
For compound 4 the middle estimate is 1.5-fold (0.17 log units) below the measured one, and the stated range covers the measured number.
By their numbers in this assay, from the lowest: compounds 2, 1, 4 and 3 (each within the scatter of the next).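

With a 1.5-fold higher number from compound 2 to compound 4 (0.18 log units; within the scatter) as the step, the first change shown at the amine nitrogen in the ring stays within the scatter. On this pair, then, 2,4-dichlorobenzyl can give way to a group with a hydrogen-bond donor and a double bond outside aromatic rings without a shift beyond the scatter. No measurement here offers an explanation for this step.

Still open, from the compounds shown here alone, is whether a plain amine hydrogen, a methyl or a longer chain on this nitrogen would give a step beyond the scatter. Also open, going by these compounds, is whether the new group behaves alike with 2-chlorophenyl or 3-nitrophenyl on the carbonyl carbon.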